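The source may report more compounds than this note shows. Statements on the series, on what has been measured and on what is new or still open speak of the compounds shown alone.

Measured compounds in a functional assay on Molt4/C8 cells (Homo sapiens) for inhibition; a higher number here means a weaker inhibitor, a lower number a stronger inhibitor:
- compound 1 `COc1cccc(/C=C2\CCCc3ccccc3C2=O)c1OC`: > 500000 nM.
- compound 2 `O=C1/C(=C/c2ccccc2F)CCc2ccccc21`: 36000 nM.
- compound 3 `O=C1/C(=C/c2ccccc2[N+](=O)[O-])CCc2ccccc21`: 8120 nM.

For compound 1 the value in this assay is a limit of the assay, not a number. Among the two numbers, compound 3 stands lowest; compound 2 is the nearest, shown by a 4.4-fold lower number from compound 2 to compound 3 (0.65 log units; beyond the scatter).

Compound 4 `Cc1ccccc1/C=C1\CCc2ccccc2C1=O` has not been measured. Its change from compound 3: methyl in place of nitro on an aromatic carbon. Going by the values given here, the one measured step that bears on it is a 4.4-fold lower number from compound 2 to compound 3 (0.65 log units; beyond the scatter), a modest step in which nitro entered in place of fluoro. Compound 4 removes the nitro again, so the step is expected to run back toward the level of compound 2, giving a modestly higher number in this assay, estimated as a 3.1-fold higher number from compound 3 to compound 4 (0.49 log units; beyond the scatter). Compound 4 is therefore expected at 25000 nM, within 8000 nM to 80000 nM.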

Compound 4, half-maximal inhibitory concentration: 41400 nM
The estimate for compound 4 lay 1.7-fold (0.22 log units) below the measured number, within the range that was stated.
By their numbers in this assay, from the lowest: compound 3; then compounds 2 and 4 (each within the scatter of the next). At a limit, above all of these: compound 1.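

In this assay, methyl in place of nitro on this aromatic carbon, ortho to a large group, gives a 5.1-fold higher number from compound 3 to compound 4 (0.71 log units; beyond the scatter), so the advantage of nitro over fluoro is not shared by methyl. Methyl and fluoro at this place cannot be separated, with a 1.2-fold higher number from compound 2 to compound 4 (0.06 log units; within the scatter). Of the three groups compared here, only nitro stands apart from the other two.

Nothing measured here explains this difference. From the compounds shown here alone, whether an amine or a nitrile on the same carbon would match nitro remains open.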